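The compounds below may be only part of what the source reports. "The series", "measured", "known", "first", "only" and "open" are said of these compounds alone.

Measured compounds:
Compound 1 `Fc1cccc(-c2nc(Nc3ccccc3)c3ccccc3n2)c1` — in a functional assay on MCF7 cells (Homo sapiens) for cytotoxicity, read by MTT assay, with a stated time of 48 h (on this read-out higher numbers stand for weaker inhibition and lower numbers for stronger inhibition), compound 1 gives > 50000 nM, which is a limit of the assay and not a number.
Compound 2 `Fc1ccc2nc(-c3ccccc3)nc(Nc3ccccc3)c2c1` — in this assay compound 2 gives > 50000 nM, again a limit.
Compound 3 `Fc1cccc(-c2nc(Nc3ccccc3F)c3cc(F)ccc3n2)c1` — in this assay compound 3 gives > 50000 nM, also a limit.

Compound 3 therefore stands nowhere in particular on a scale of numbers: all three measured compounds sit at the limit of > 50000 nM in this assay, at which 3 of the 3 values shown sit, and none of them has a measured value that could order it against the others. Among the measured compounds shown here, no step between measured compounds can be read from these data.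

Compound 4 `Oc1ccccc1Nc1nc(-c2cccc(F)c2)nc2ccc(F)cc12` is the next compound to be measured in this assay. It differs from compound 3 in one place: hydroxy in place of fluoro on an aromatic carbon. Whether a hydroxy in place of fluoro on an aromatic carbon changes the outcome cannot be taken from the three compounds, since they show only limits.

For the measured compounds named here, the step that the limit leaves unreadable from compound 3 to compound 4 is expected to be none beyond the scatter, because compound 3 sits at the limit of > 50000 nM in this assay, at which 3 of the 3 values shown sit, and nothing among the measured compounds points to a change. Compound 4 is expected to give about 80000 nM in this assay, most likely again only a limit, with a range from 20000 nM to 300000 nM.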

Compound 4, half-maximal inhibitory concentration: > 50000 nM
Compound 4: only a limit was reported; the forecaster's own chance of this, stated with the estimate: 75%; the middle value lies beyond the limit too.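

No new step can be read from compound 3 to compound 4, with hydroxy in place of fluoro on an aromatic carbon, because both stand at a limit of the assay and not at a number: the limit of > 50000 nM in this assay, at which 4 of the 4 values shown sit.

The compounds shown leave open which change to the shared core, if any, would give a measurable value in this assay.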